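The source may report more compounds than this note shows. Statements on the series, on what has been measured and on what is new or still open speak of the compounds shown alone.

Of the compounds shown here, three have been measured in a functional assay on HeLa cells (Homo sapiens) for antiproliferative activity, read by MTT assay, with a stated time of 72 h; on this read-out higher numbers stand for weaker inhibition and lower numbers for stronger inhibition. Compound 1 `CN(Cc1ccccc1)C(=S)SCC1=CC(=O)OC1` gives > 50 ug/mL, which is a limit of the assay rather than a number. Compound 3 `O=C1CC2(CO1)CSC(=S)N2Cc1ccccc1` likewise gives > 50 ug/mL, also a limit. Compound 2 `O=C1CC2(CO1)CSC(=S)N2c1ccc(F)cc1` gives > 50 ug/mL, again a limit, so compound 2 stands with the others at the limit of > 50 ug/mL in this assay, at which 3 of the 3 values shown sit, and no ordering among them can be drawn. Compound 4 `O=C1CC2(CO1)CSC(=S)N2c1ccc(Cl)cc1` differs from compound 2 by chloro in place of fluoro on an aromatic carbon. Among the compounds with values here, no measured pair separated by a single change is available, so the step is expected to be small, within the scatter and in no particular direction, estimated as a step that the limit leaves unreadable from compound 2 to compound 4. Compound 4 is expected to give 60 ug/mL, between 20 ug/mL and 200 ug/mL, most likely reported once more only as a limit.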

Compound 4, half-maximal inhibitory concentration: > 50 ug/mL
Compound 4: a limit, no number; the forecaster's own chance of this, stated with the estimate: 80%; the middle value does not contradict the limit.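

No step can be read from compound 2 to compound 4, because both results are limits of the assay rather than numbers: the limit of > 50 ug/mL in this assay, at which 4 of the 4 values shown sit. The compounds shown leave open how these four rank against one another and whether any change to them would give a readable value.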